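This account rests on a few compounds, and the source may have more. Where it says the series, first, only, none or still open, it means among the compounds named here.

Two compounds from this set carry the same core and differ only in the aromatic group at the end of the chain. Compound 1 `COC1=C(C)C(=O)/C(=C(O)/C=C/c2ccccc2OC)C(=O)C1(C)C` gives 2.4 ug/mL in a functional assay on A549 cells (Homo sapiens) for cytotoxicity; a lower number here means that less compound is needed, a higher number that more compound is needed for the effect. Compound 2 `COC1=C(C)C(=O)/C(=C(O)/C=C/c2cccc3ccccc23)C(=O)C1(C)C` gives 3.6 ug/mL in this assay. Compound 1 shows the smaller of the two numbers, but the gap to compound 2 lies within the usual scatter, so the two cannot be ranked against each other.

Compound 3 `COC1=C(C)C(=O)/C(=C(O)/C=C/c2ccco2)C(=O)C1(C)C` has not yet been measured in this assay. It differs from compound 1 in one place: furan-2-yl in place of 2-methoxyphenyl on a double-bonded chain carbon bound to a double-bonded chain carbon. Among the compounds with values here, no measured pair in this set tells how such a swap shifts the number, so the expectation rests on compound 1 alone and on the small size of the change. A step of a 1.7-fold higher number from compound 1 to compound 3 (0.22 log units; within the scatter) is expected, a modest rise that may stay within the scatter. Compound 3 is estimated at 4 ug/mL, with a range from 1.5 ug/mL to 12 ug/mL.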

Compound 3, concentration for half-maximal effect: 10 ug/mL
The estimate for compound 3 lay 2.5-fold (0.40 log units) below the measured number; the measured number falls inside the stated range.
By their numbers in this assay, from the lowest: compounds 1 and 2 (each within the scatter of the next); then compound 3.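

Compounds 1 and 2 sat too close together to show whether the aromatic group at the end of the chain matters, but this change gives a clear answer in this assay: furan-2-yl in place of 2-methoxyphenyl brings a 4.2-fold higher number from compound 1 to compound 3 (0.62 log units; beyond the scatter). The group at this place on the chain can therefore move the number beyond the usual scatter, and in this swap the change is towards more compound being needed. No supporting measurement is at hand to explain the shift.

A single swap replaces the six-membered carbon ring and its methoxy group in one move, so it cannot tell which of these differences accounts for the step. Going by these compounds, a plain phenyl group or a pyridine ring at the same place would be needed to separate them, and how either would behave remains open.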